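Chloro in place of hydrogen and cytotoxicity: compound 4

The compounds below may be only part of what the source reports. "The series", "measured", "known", "first", "only" and "open" are said of these compounds alone.

Measured so far:
Compound 1, `O=c1ccn(CCOc2ccccc2Oc2cccc3cc(Cl)ccc23)c(=O)[nH]1`, gives > 100000 nM in an ADME assay on MT2 cells (Homo sapiens) for cytotoxicity, read by MTT assay; on this read-out higher numbers stand for lower toxicity in this test and lower numbers for higher toxicity in this test.
Compound 2, `O=c1ccn(CCOc2ccccc2Oc2cc(Cl)cc3cc(Cl)ccc23)c(=O)[nH]1`, gives 45000 nM.
Compound 3, `N#Cc1ccc2c(Oc3ccccc3OCCn3ccc(=O)[nH]c3=O)cc(Cl)cc2c1`, gives 24000 nM.

For the measured compounds named here, the value of compound 1 in this assay is a limit of the assay, not a number, and it is the one value sitting at the limit of > 100000 nM in this assay, at which 1 of the 3 values shown sits. Compound 2 carries chloro in place of hydrogen on an aromatic carbon, described as chloro in place of hydrogen on an aromatic carbon, and this gives an at least 2.2-fold lower number from compound 1 to compound 2 (0.34 log units; beyond the scatter). Compound 3 follows with cyano in place of chloro, a change that gives a 1.9-fold lower number from compound 2 to compound 3 (0.27 log units; within the scatter), so the values of compound 2 and compound 3 are not distinguished here.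

Compound 4, `N#Cc1ccc2c(Oc3ccc(Cl)cc3OCCn3ccc(=O)[nH]c3=O)cc(Cl)cc2c1`, has not yet been measured in this assay. It differs from compound 3 by chloro in place of hydrogen on an aromatic carbon. Going by the values given here, this is the same kind of change as the one from compound 1 to compound 2, but the place is not the same: in compound 2 the chloro sits on a ring that is part of a fused or bridged system of two rings, meta to a fused ring and para to a fused ring, whereas in compound 4 it sits on a six-membered aromatic ring of carbon only that is not fused, meta to a large group and para to a large group. The difference between the core of compound 1 and the core of compound 3 is not broken down here.

Resting on compound 2 and its step of an at least 2.2-fold lower number from compound 1 to compound 2 (0.34 log units; beyond the scatter), a comparable lowering of the number is expected for compound 4, namely a 2.0-fold lower number from compound 3 to compound 4 (0.30 log units; within the scatter). Compound 4 is therefore estimated at 12000 nM, expected to lie between 5000 nM and 30000 nM.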

Compound 4, half-maximal cytotoxic concentration: 20000 nM
Compound 4: the middle estimate sits 1.7-fold (0.22 log units) below what was measured, within the range that was stated.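

In this assay, chloro in place of hydrogen on an aromatic carbon of the six-membered aromatic ring of carbon only gives a 1.2-fold lower number from compound 3 to compound 4 (0.08 log units; within the scatter), so this step does not separate the two compounds. The chloro also sits on a different ring in the two steps, so core and place are not separated here, and the data show neither that the larger shift carries over from one core to the other nor that it fails to: the same change on two cores in this assay, an at least 2.2-fold lower number (0.34 log units; beyond the scatter) from compound 1 to compound 2 and a 1.2-fold lower number (0.08 log units; within the scatter) from compound 3 to compound 4; the limit leaves it open whether they differ Compound 1 gives > 100000 nM, which is a limit of the assay and not a number.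

The compounds shown leave open how fluoro, methoxy or an amine would read in this assay on the aromatic carbon that carries the new chloro in compound 4. They also leave open whether a carboxylic acid on the shared core or a longer chain in place of the one present would give a step beyond the scatter.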